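Swapping the aryl group on compound 1's triazole core

The compounds below may be only part of what the source reports. "The series", "measured", "known", "first", "only" and "open" are said of these compounds alone.

Measured compounds:
compound 1 `O=C(NO)c1ccc(NCc2nc(-c3cccc4cnccc34)nn2-c2ccccc2)cc1` gives 40.2%
compound 2 `O=C(NO)c1ccc(NCc2nc(-c3ccccc3)nn2-c2ccc(Br)cc2)cc1` gives 65.9%
compound 3 `O=C(NO)c1ccc(NCc2nc(-c3ccccc3)nn2-c2cccc(Cl)c2)cc1` gives 62.3%

All three share a hydroxamic acid attached through a linker to a five-membered ring that carries two aromatic groups, and all were tested in an assay on Sf9 cells for inhibition of protein deacetylase HDAC6 (Homo sapiens), read by fluorescence, with a stated time of 40 min, tested at 100 nM; a lower number here means less inhibition, a higher number more inhibition at the concentration tested (going by the name of the read-out). Compound 1 stands lowest of the three: in this assay compound 1 gives 40.2%, while compound 3 gives 62.3% and compound 2 gives 65.9%, both beyond the scatter above compound 1.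

The unmeasured compound 4 `O=C(NO)c1ccc(NCc2nc(-c3cc4ccccc4s3)nn2-c2ccccc2)cc1` differs from compound 1 in one place: 1-benzothiophen-2-yl in place of isoquinolin-5-yl on an aromatic carbon. For the measured compounds named here, the only measured step, a number 3.6 percentage points lower from compound 2 to compound 3 (within the scatter), concerns the group on the aromatic nitrogen, not the aromatic carbon, so it does not bear on this change directly. What the data do show is that compound 1, with isoquinolin-5-yl, lies below compound 2 and compound 3, which carry phenyl at that carbon. Since compound 4 carries a bicyclic group again, but a different one, the expectation is an intermediate outcome: compound 4 is expected to give 50%, within 25% to 75%, an expected step of a number 9.8 percentage points higher from compound 1 to compound 4 (within the scatter).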

Compound 4, a percentage reported as inhibition, at one concentration (the size of the read-out at that concentration, not a potency): 65.5%
For compound 4 the middle estimate is 15.5 percentage points below the measured one; the measured number falls inside the stated range.
By their numbers in this assay, from the lowest: compound 1; then compounds 3, 4 and 2 (each within the scatter of the next).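

With everything else in the molecule unchanged, this assay shows that the group on this aromatic carbon can shift the read-out: replacing isoquinolin-5-yl with 1-benzothiophen-2-yl gives a number 25.3 percentage points higher from compound 1 to compound 4 (beyond the scatter), a step beyond the scatter. The earlier one-place comparison concerned only the group on the aromatic nitrogen and gave a number 3.6 percentage points lower from compound 2 to compound 3 (within the scatter), so it said nothing about this carbon; the new pair also shows that having two aromatic rings in this group does not by itself settle the number, as isoquinolin-5-yl and 1-benzothiophen-2-yl each have two. No measurement available here explains the difference between these two groups.

The compounds shown leave open whether this step follows the sulfur atom, the five-membered ring, the loss of the ring nitrogen or the different point of attachment, as all of these change together in this one swap. Comparing 1-benzofuran-2-yl, which keeps the five-membered ring but has oxygen in place of sulfur, and naphthalen-2-yl, which has only six-membered carbon rings, on the same carbon would help to separate these features.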